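A few compounds are considered here, and "the series" means these few. Any claim that something is new, unique, unknown or untested is made for them only; others in the source may bear on it.

For the measured compounds named here, in an assay on cells for displacement of a labelled ligand from Glucagon receptor (Homo sapiens), in the presence of a further agent that is not named here (on this read-out lower numbers stand for stronger inhibition and higher numbers for weaker inhibition), compound 1 `O=C(O)CCNC(=O)c1ccc(C(Oc2ccc(-n3cc(C(F)(F)F)cn3)cc2)C2CC2)cc1` gives 1300 nM, the highest of the three numbers measured so far. Compound 2 `CCCC(Oc1ccc(-n2cc3ccccc3n2)cc1)c1ccc(C(=O)NCCC(=O)O)cc1` gives 290 nM in this assay, and compound 3 `CCCC(Oc1ccc(-n2cc(C(F)(F)F)c(C)n2)cc1)c1ccc(C(=O)NCCC(=O)O)cc1` gives 1100 nM. Against compound 3 the number of compound 1 lies within the scatter; against compound 2 it lies beyond it. Going by the values given here, the single step between measured compounds that differ in one place, a 3.8-fold higher number from compound 2 to compound 3 (0.58 log units; beyond the scatter), concerns the group on the aromatic ring and leaves the saturated chain carbon untouched.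

Compound 4 `O=C(O)CCNC(=O)c1ccc(C(Oc2ccc(-n3cc(C(F)(F)F)cn3)cc2)C2CCCC2)cc1` differs from compound 1 by cyclopentyl in place of cyclopropyl on a saturated chain carbon bound to an aromatic carbon and an oxygen on an aromatic ring. Among the compounds with values here, no measured step bears on this place: compound 2 and compound 3 both carry a group there that is neither cyclopropyl nor cyclopentyl, and no pair of measured compounds differs only at that carbon. With nothing closer to rest on than the number of compound 1 itself, the step from compound 1 to compound 4 is estimated as a 1.3-fold lower number from compound 1 to compound 4 (0.11 log units; within the scatter), which is to say no change beyond the scatter, and the range is set wide to reflect that. Compound 4 is therefore expected to give 1000 nM in this assay, with a range from 350 nM to 3000 nM.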

Compound 4, inhibition constant: 420 nM
For compound 4 the middle estimate is 2.4-fold (0.38 log units) above the measured one; the range from low to high includes it.
By their numbers in this assay, from the lowest: compounds 2 and 4 (each within the scatter of the next); then compounds 3 and 1 (each within the scatter of the next).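

In this assay, replacing cyclopropyl with cyclopentyl on the saturated chain carbon bound to an aromatic carbon and an oxygen on an aromatic ring gives a 3.1-fold lower number from compound 1 to compound 4 (0.49 log units; beyond the scatter), so the number responds to the group at this carbon and not only to the group changed in the earlier step. With the rest of the structure of compound 1 held fixed, this single pair links a ring of 5 heavy atoms, in place of one of 3 heavy atoms, to a lower number, although one pair cannot establish a trend with ring size. Nothing shown here accounts for this step.

The compounds shown leave open where a cyclobutyl or a cyclohexyl group at this carbon would fall, and how cyclopentyl would compare with the open chain carried there by compound 2 and compound 3. They also leave open whether the same exchange would lower the number in a compound bearing the 2H-indazol-2-yl group of compound 2.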